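The source may report more compounds than this note shows. Statements on the series, on what has been measured and on what is new or still open speak of the compounds shown alone.

Of the compounds shown here, three of the same shared core have been measured in an assay on cells for inhibition of ubiquitin carboxyl-terminal hydrolase 8 (Homo sapiens), read by fluorescence, with a stated time of 30 min; on this read-out lower numbers stand for stronger inhibition and higher numbers for weaker inhibition. Compound 1 `Cc1n[nH]c(C)c1Oc1c(O)cc(O)c2c(=O)cc(-c3ccc(N4CCCNCC4)cc3)oc12` gives 17600 nM, compound 2 `Cc1n[nH]c(C)c1Oc1c(O)cc(O)c2c(=O)cc(-c3ccc(N4CCN(C(C)C)CC4)cc3)oc12` gives 16300 nM, and compound 3 `O=c1cc(-c2ccc(N3CCCNCC3)cc2)oc2c(OC3CCCCC3)c(O)cc(O)c12` gives 16200 nM. Compound 2 sits second highest of the three numbers; its value and that of compound 3 lie within the scatter of each other, and the step of a 1.1-fold lower number from compound 1 to compound 2 (0.03 log units; within the scatter) is likewise within the scatter. The other recorded step, a 1.1-fold lower number from compound 1 to compound 3 (0.04 log units; within the scatter), alters a different part of the molecule and also stays within the scatter.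

Compound 4 `Cc1n[nH]c(C)c1Oc1c(O)cc(O)c2c(=O)cc(-c3ccc(N4CCN(C(=O)c5ccco5)CC4)cc3)oc12` differs from compound 2 in one place: (furan-2-yl)carbonyl in place of isopropyl on an amine nitrogen in a ring. Going by the values given here, the step most relevant to it is the one from compound 1 to compound 2, which also altered the group on the aromatic carbon bearing the ring amine and yielded no change beyond the scatter. Among the compounds with values here, no measured step replaces a group on the ring nitrogen itself, so the evidence is indirect. Given that every recorded step in this assay is within the scatter, the step from compound 2 to compound 4 is expected to be a 1.0-fold lower number from compound 2 to compound 4 (0.01 log units; within the scatter), in no particular direction. Compound 4 is therefore estimated at 16000 nM, with a range from 7000 nM to 36000 nM.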

Compound 4, half-maximal inhibitory concentration: 5100 nM
For compound 4 the middle estimate is 3.1-fold (0.50 log units) above the measured one; the whole stated range lies above it.
By their numbers in this assay, from the lowest: compound 4; then compounds 3, 2 and 1 (each within the scatter of the next).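

In this assay, putting (furan-2-yl)carbonyl in place of isopropyl on the amine nitrogen in the six-membered non-aromatic ring gives a 3.2-fold lower number from compound 2 to compound 4 (0.50 log units; beyond the scatter) and is the only step shown that lies beyond the scatter. Going by these compounds alone, the earlier steps, a 1.1-fold lower number from compound 1 to compound 2 (0.03 log units; within the scatter) and a 1.1-fold lower number from compound 1 to compound 3 (0.04 log units; within the scatter), stayed within it, so this is the first sign that the number responds to a structural change, here to the group on this ring nitrogen. The change brings in a carbonyl, a five-membered aromatic ring and hydrogen-bond acceptors all at once, and no measurement separates these features or bears on the cause of the lower number.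

The compounds shown leave open whether the carbonyl alone is enough, as an acetyl group on the same nitrogen would show, or whether the furan ring matters, as a benzoyl group or a thiophene-2-carbonyl group would show. They also leave open whether (furan-2-yl)carbonyl has a similar effect when cyclohexyl replaces 3,5-dimethyl-1H-pyrazol-4-yl on the oxygen.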